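Shortening the chain on the shared core: compound 3 to compound 4

This account rests on a few compounds, and the source may have more. Where it says the series, first, only, none or still open, it means among the compounds named here.

Measured so far:
- compound 3 `CC(C)=CCC/C(C)=C/COc1ccc(C2CC2C(=O)NNc2nncc3ccccc23)cc1` — 9000 nM
- compound 1 `CC(C)=CCC/C(C)=C/COc1ccc(C2CC2C(=O)NNC(=O)c2ccncc2)cc1` — "not determined" (no result reported)
- compound 2 `CC(C)=CCOc1ccc(C2CC2C(=O)NNC(=O)c2ccncc2)cc1` — "not determined" (no result reported)

Within the data shown here, in a functional assay on OE21 cells (Homo sapiens) for inhibition, read by MTT assay, with a stated time of 72 h (on this read-out higher numbers stand for weaker inhibition and lower numbers for stronger inhibition), compound 3 gives 9000 nM, and it is the only compound here with a number; in this assay compound 1 gives "not determined" (no result reported) and compound 2 gives "not determined" (no result reported). Compound 4 `CC(C)=CCOc1ccc(C2CC2C(=O)NNc2nncc3ccccc23)cc1` differs from compound 3 by one change: hydrogen in place of 3-methylbut-2-en-1-yl on a saturated chain carbon bound to a double-bonded chain carbon. Among the measured compounds shown here, no step between two measured compounds shows what such a change does to inhibition in this assay, so the direction is open. On balance a modest loss of inhibition is expected, with the step from compound 3 to compound 4 estimated as a 1.7-fold higher number from compound 3 to compound 4 (0.22 log units; within the scatter). For compound 4 the estimate in this assay is 15000 nM, with a range from 5000 nM to 50000 nM.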

Compound 4, half-maximal inhibitory concentration: 38000 nM
Estimate against measurement, compound 4: 2.5-fold (0.40 log units) below; measured number inside the range.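

In this assay, among these compounds, shortening 3,7-dimethylocta-2,6-dien-1-yl to 3-methylbut-2-en-1-yl gives a 4.2-fold higher number from compound 3 to compound 4 (0.63 log units; beyond the scatter), the first step here to show that this chain position affects inhibition, with the longer chain giving the lower number. No supporting data accompany this result to account for the step. Going by these compounds, whether a still longer chain would lower the number further, or a terminal amine or carboxylic acid would retain inhibition, remains open. The same shortening from compound 1 to compound 2 cannot be read, since neither compound has a number.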